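Cyclohexyl in Place of Phenyl on the Sulfonyl Group

The compounds below may be only part of what the source reports. "The series", "measured", "known", "first", "only" and "open" are said of these compounds alone.

Compound 1, `N#C/N=C(\NCc1ccc(S(=O)(=O)c2ccccc2)cc1)Nc1cccnc1`, gives 2.2 nM.
Compound 2, `COc1cccc(S(=O)(=O)c2ccc(CN/C(=N\C#N)Nc3ccncc3)cc2)c1`, gives 1.9 nM.
Compound 3, `N#C/N=C(\NCc1ccc(S(=O)(=O)c2ccccc2)cc1)Nc1ccncc1`, gives 2.5 nM.

All three were tested in an assay on isolated protein for inhibition of Nicotinamide phosphoribosyltransferase (Homo sapiens), read by mass spectrometry, with stated times of 15 min and 30 min; a higher number here means a weaker inhibitor, a lower number a stronger inhibitor. Compound 3 has the highest of the three numbers, but both of its neighbours sit within the scatter: a 1.1-fold higher number from compound 1 to compound 3 (0.06 log units; within the scatter) and a 1.3-fold higher number from compound 2 to compound 3 (0.12 log units; within the scatter). On these numbers the three compounds cannot be told apart.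

Compound 4, `N#C/N=C(\NCc1ccc(S(=O)(=O)C2CCCCC2)cc1)Nc1ccncc1`, differs from compound 3 in one place: cyclohexyl in place of phenyl on a sulfonyl sulfur. Neither measured step touches the group on the sulfonyl sulfur; one moves the attachment point of the pyridyl ring, the other removes a methoxy from an aromatic carbon. Among the measured compounds shown here, no measured step therefore bears on this change, and the expectation rests only on the value of compound 3, 2.5 nM, as a starting point. With nothing to guide the direction, a moderate weakening is a plausible guess, but the range must stay wide; the expected step is a 2.4-fold higher number from compound 3 to compound 4 (0.38 log units; beyond the scatter). Compound 4 is estimated at 6 nM, with a range from 1.5 nM to 40 nM.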

Compound 4, half-maximal inhibitory concentration: 5.4 nM
Estimate against measurement, compound 4: 1.1-fold (0.05 log units) above, within the range that was stated.
By their numbers in this assay, from the lowest: compounds 2, 1 and 3 (each within the scatter of the next); then compound 4.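

Among the compounds shown here, the earlier steps all stayed within the scatter, so the group on the sulfonyl sulfur is the first place in this set where a change shifts the number in this assay beyond it (a 2.2-fold higher number from compound 3 to compound 4 (0.33 log units; beyond the scatter)). Measured against the 3-methoxyphenyl group, cyclohexyl gives a modest step of the same kind (a 2.8-fold higher number from compound 2 to compound 4 (0.45 log units; beyond the scatter)), so an aromatic ring on the sulfonyl sulfur is not essential, as compound 4 still gives 5.4 nM. Nothing measured here explains why the non-aromatic ring gives the higher number.

The compounds shown leave open how a much smaller group such as methyl, a longer alkyl chain or a ring carrying an amine would behave on the sulfonyl sulfur. They also leave open whether cyclohexyl would give a similar step with pyridin-3-yl in place of pyridin-4-yl.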